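The compounds below may be only part of what the source reports. "The series", "measured", "known", "first", "only" and "open" are said of these compounds alone.

Compound 3, with the structure `COc1cc(C2=NN(C(C)=O)C(c3ccc(Cl)c([N+](=O)[O-])c3)O2)cc(OC)c1OC`, gives 61.4% in a functional assay on PC-3 cells (Homo sapiens) for antiproliferative activity, read by MTT assay, tested at 5 uM (on this read-out lower numbers stand for a weaker effect and higher numbers for a stronger effect at the one concentration tested), and this is the highest of the three numbers measured in this series. Compound 2, `COc1ccc(OC)c(C2OC(c3cc(OC)c(OC)c(OC)c3)=NN2C(C)=O)c1`, comes nearest with 43.2%, while compound 1, `COc1cc(C2=NN(C(C)=O)C(c3c(Cl)cccc3Cl)O2)cc(OC)c1OC`, is furthest away at -2.2%. The three compounds share one core and differ only in the aryl group on a saturated ring carbon. The steps measured there have all been large or modest and all beyond the scatter: a number 45.4 percentage points higher from compound 1 to compound 2 (beyond the scatter), a number 63.6 percentage points higher from compound 1 to compound 3 (beyond the scatter) and a number 18.2 percentage points higher from compound 2 to compound 3 (beyond the scatter). Compound 4, `COc1cc(C2=NN(C(C)=O)C(c3ccc(F)c(F)c3)O2)cc(OC)c1OC`, has not yet been measured, and it differs from compound 3 in the same place: 3,4-difluorophenyl in place of 4-chloro-3-nitrophenyl on a saturated ring carbon.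

Going by the values given here, no measured step involves a 3,4-difluorophenyl group, so the bearing of the three steps is indirect; they show only that the aryl group on this carbon moves the read-out strongly, and that the 4-chloro-3-nitrophenyl of compound 3 stands at the top. Since compound 3 holds the highest value, the step to compound 4 is expected to go downward rather than upward, by an amount estimated as a number 21.4 percentage points lower from compound 3 to compound 4 (beyond the scatter). Compound 4 is therefore expected to give about 40% in this assay, with a likely range from 10% to 65%.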

Compound 4, a percentage reported as inhibition, at one concentration (the size of the read-out at that concentration, not a potency): 46.9%
Beside the measured number, compound 4's estimate is 6.9 percentage points below it, within the range that was stated.
By their numbers in this assay, from the lowest: compound 1; then compounds 2 and 4 (each within the scatter of the next); then compound 3.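

In this assay, replacing 4-chloro-3-nitrophenyl on the saturated ring carbon with a group of carbon and fluorine only comes to a number 14.5 percentage points lower from compound 3 to compound 4 (beyond the scatter) and so lowers the read-out without abolishing it. Going by these compounds alone, the 3,4-difluorophenyl group also adds a comparison the earlier compounds lacked: against 2,5-dimethoxyphenyl the change is a number 3.7 percentage points higher from compound 2 to compound 4 (within the scatter) and cannot be read as a difference, while against 2,6-dichlorophenyl it is a number 49.1 percentage points higher from compound 1 to compound 4 (beyond the scatter) and shows that two aryl groups that both carry two halogen atoms can lie far apart on this read-out. No measurement is available here that explains any of these differences.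

The compounds shown leave open whether the chlorine or the nitro group of 4-chloro-3-nitrophenyl contributes more to the read-out of compound 3, and whether a single fluorine would serve as well as the two in compound 4. Also open, going by these compounds, is what a dimethylamino group or a carboxylic acid on this aryl ring would do in this assay at this position of the shared core.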